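Compound 3 as the next step after compound 2

A few compounds are considered here, and "the series" means these few. Any claim that something is new, unique, unknown or untested is made for them only; others in the source may bear on it.

compound 1 `COC(=O)C1=C(C)N=C(C)/C(=C(/O)OC)C1c1ccccc1OCc1no[n+]([O-])c1C`: 43 nM
compound 2 `COC(=O)C1=C(C)N=C(C)/C(=C(/O)OC)C1c1ccccc1OCc1no[n+]([O-])c1C(N)=O`: 550 nM

Among the measured compounds shown here, in a functional assay (aorta) with Rattus norvegicus as the target, in the presence of a further agent that is not named here (a lower number here means that less compound is needed, a higher number that more compound is needed for the effect), compound 2 gives 550 nM, the higher of the two numbers so far. Compound 3 `COC(=O)C1=C(C)N=C(C)/C(=C(/O)OC)C1c1ccccc1OCc1nonc1C#N` replaces the group of compound 2: a group of 7 heavy atoms (3 carbon, 3 nitrogen, 1 oxygen; one five-membered aromatic ring with 3 hetero atoms) in place of a group of 9 heavy atoms (3 carbon, 3 nitrogen, 3 oxygen; one five-membered aromatic ring with 3 hetero atoms), on a saturated chain carbon bound to an oxygen on an aromatic ring. The entering group is 4-cyano-1,2,5-oxadiazol-3-yl.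

For the measured compounds named here, one measured step bears on this, and only indirectly: a 13-fold higher number from compound 1 to compound 2 (1.11 log units; beyond the scatter), with carbamoyl in place of methyl on an aromatic carbon. That large step shows that a change within this part of the molecule can shift the number well beyond the scatter. However, it does not measure the replacement made in compound 3, so the direction remains uncertain. A moderate move to a lower number in this assay is tentatively expected, with a wide margin. The expected step is a 2.2-fold lower number from compound 2 to compound 3 (0.34 log units; beyond the scatter). For compound 3 the estimated value is 250 nM, with an expected range of 50 nM to 1200 nM.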

Compound 3, half-maximal effective concentration: 6.6 nM
Compound 3: middle estimate off by 38-fold (1.58 log units), on the high side; the whole stated range lies above it.
By their numbers in this assay, from the lowest: compound 3; then compound 1; then compound 2.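

In this assay the 4-cyano-1,2,5-oxadiazol-3-yl group, on a saturated chain carbon bound to an oxygen on an aromatic ring, gives the lowest number of the three compounds, with an 83-fold lower number from compound 2 to compound 3 (1.92 log units; beyond the scatter) and a 6.5-fold lower number from compound 1 to compound 3 (0.81 log units; beyond the scatter) as the two new steps. The earlier step showed only an upward move from this part of the molecule; the new steps show that it can also move the number downward, past both earlier groups. Nothing available explains this shift.

Going by these compounds, both new steps change the five-membered ring and its substituent together, so the contribution of the nitrile alone remains open. Also open, on these data alone, is how a carboxylic acid or an aminomethyl group in place of the nitrile would read.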